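Branching the thioester chain in a lipophilicity series

This account rests on a few compounds, and the source may have more. Where it says the series, first, only, none or still open, it means among the compounds named here.

Of the compounds shown here, three in this set have been measured in a physicochemical assay for lipophilicity; on this read-out lower numbers stand for lower lipophilicity and higher numbers for higher lipophilicity. Compound 1 `CCCCOC(=O)/C=C(C)/C=C/CC(C)CCCC(C)(C)OC` gives 6.62, compound 2 `COC(C)(C)CCCC(C)C/C=C/C(C)=C/C(=O)OCCC(C)C` gives 7.03, and compound 3 `CCSC(=O)/C=C(C)/C=C/CC(C)CCCC(C)(C)OC` gives 6.78. Compound 3 stands between the other two in this assay, but its distances to both are within the scatter, so no order among them is claimed.

Compound 4 `COC(C)(C)CCCC(C)C/C=C/C(C)=C/C(=O)SC(C)C` has not yet been measured in this assay. It differs from compound 3 by methyl in place of hydrogen on a saturated chain carbon bound to a saturated chain carbon and a sulfur. The same kind of change has already been made once among the measured compounds: compound 2 differs from compound 1 by methyl in place of hydrogen on a saturated chain carbon bound to two saturated chain carbons, and there a number 0.41 log units higher from compound 1 to compound 2 (beyond the scatter). The two places are not identical, since in the measured pair the carbon is bound to two saturated chain carbons, whereas in the new pair it is bound to a saturated chain carbon and a sulfur. The cores of the two pairs also differ, by ethylsulfanyl in place of butoxy on a carbonyl carbon, a change that produced a number 0.16 log units higher from compound 1 to compound 3 (within the scatter).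

Within the data shown here, on this basis compound 4 is expected to come out in this assay with a number 0.42 log units higher from compound 3 to compound 4 (beyond the scatter), a step of about the size seen from compound 1 to compound 2 because that is the only measured example of this kind of change, a number 0.41 log units higher from compound 1 to compound 2 (beyond the scatter). Compound 4 is therefore estimated at 7.2, expected to fall between 6.9 and 7.5.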

Compound 4, partition coefficient: 7.19
Compound 4: middle estimate off by 0.01 log units, on the high side; the range from low to high includes it.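

In this assay, methyl in place of hydrogen gave a number 0.41 log units higher from compound 3 to compound 4 (beyond the scatter), a step of the same printed size as a number 0.41 log units higher from compound 1 to compound 2 (beyond the scatter), so across these two pairs the change carried over from one core to the other with its size intact, even though the place differs and here is on a saturated chain carbon bound to a saturated chain carbon and a sulfur. Taken against the two other compounds, isopropylsulfanyl in place of butoxy gave a number 0.57 log units higher from compound 1 to compound 4 (beyond the scatter), whereas isopropylsulfanyl in place of isopentyloxy gave a number 0.16 log units higher from compound 2 to compound 4 (within the scatter), so compound 2 and compound 4 cannot be put in any order. This agreement rests on only two pairs and shows no general rule for the series, and nothing shown bears on what lies behind the matching steps.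

The compounds shown leave open whether a step of this size would recur with a further branch such as tert-butylsulfanyl or with a longer chain on the sulfur, such as butylsulfanyl. They also leave open what an amide or a carboxylic acid would give in place of the thioester on the same carbonyl carbon.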